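The compounds below may be only part of what the source reports. "The series", "measured", "known", "first", "only" and "open" are said of these compounds alone.

Measured compounds:
compound 1 `Oc1ccc(CNc2cc(C(F)(F)F)cc3[nH]ncc23)cc1` with 81%
compound 2 `FC(F)(F)c1cc(NC[C@H]2CCCN2)c2cn[nH]c2c1` with 83%
compound 3 `O=[N+]([O-])c1cc(OCc2ccccc2)ccc1CNc1cc(C(F)(F)F)cc2[nH]ncc12` with 20%

In an assay for inhibition of Indoleamine 2,3-dioxygenase 1 (Homo sapiens), with stated times of 10 min and 60 min, tested at 100 uM (on this read-out lower numbers stand for a weaker effect and higher numbers for a stronger effect at the one concentration tested), compound 1 gives 81%. Compound 2 stands close to it: the change a number 2 percentage points higher from compound 1 to compound 2 (within the scatter) is within the scatter, so the two are not told apart. Compound 3 is far away, its 20% lying well beyond the scatter from compound 1. Compound 1 therefore sits with compound 2 at the strong end of the three values shown.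

Compound 4 `Oc1ccc(CNc2cc(C(F)(F)F)cc3[nH]ncc23)c(Cl)c1` differs from compound 1 by chloro in place of hydrogen on an aromatic carbon. None of the measured steps bears directly on this change: the one step shown swaps the whole aromatic ring for a pyrrolidin-2-yl, which is a different kind of alteration, and no pair among the measured compounds adds a single chloro to the hydroxyphenyl ring. Because the step of a number 2 percentage points higher from compound 1 to compound 2 (within the scatter) shows the read-out holding when even a larger part of that end is replaced, compound 4 is expected to stay near compound 1, with a step of a number 1 percentage points lower from compound 1 to compound 4 (within the scatter) not expected to exceed the scatter. For compound 4 the estimate is 80%, in the range 62% to 94%.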

Compound 4, a percentage reported as inhibition, at one concentration (the size of the read-out at that concentration, not a potency): 95%
Beside the measured number, compound 4's estimate is 15 percentage points below it, outside the stated range (above it).
By their numbers in this assay, from the lowest: compound 3; then compounds 1 and 2 (each within the scatter of the next); then compound 4.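

In this assay the single chloro in place of hydrogen gives a number 14 percentage points higher from compound 1 to compound 4 (beyond the scatter), so this end of the molecule responds to a change of one heavy atom. The earlier step at this end, a far larger replacement, stayed within the scatter and gave no sign of this; the aromatic carbon ortho to a large group and meta to a hydroxy group now appears as a place that accepts chloro with a modest gain rather than a loss. Nothing measured here accounts for that gain.

The compounds shown leave open whether fluoro, bromo or methyl on this same carbon would give a similar step, or whether chloro on the other carbons of this ring would do so. They also leave open whether the gain survives with a methoxy group in place of the hydroxy group.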